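The source may report more compounds than this note shows. Statements on the series, on what has been measured and on what is new or still open speak of the compounds shown alone.

Working notes on the series. Two compounds have been run so far. Compound 1 `Oc1cc(Cc2cc(O)c(O)c(Br)c2Br)c(Br)c(Br)c1O` is the parent without an ether chain; in a functional assay on A549 cells (Homo sapiens) for cytotoxicity, read by MTT assay, with a stated time of 96 h (on this read-out higher numbers stand for weaker inhibition and lower numbers for stronger inhibition), compound 1 gives 1800 nM. Compound 2 `CCOCc1cc(O)c(O)c(Br)c1Cc1cc(O)c(O)c(Br)c1Br` carries an ethoxymethyl on one ring. In this assay compound 2 returns only a limit, > 19000 nM, and no number. The two results therefore do not form a measurable step; what they show is that compound 1 gives a value where compound 2 does not, as recorded in the limit of > 19000 nM in this assay, at which 1 of the 2 values shown sits. Compound 2 thus stands at the weak end of what is known here.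

Compound 3 `COCc1cc(O)c(O)c(Br)c1Cc1cc(O)c(O)c(Br)c1Br` is the next member. It differs from compound 2 by hydrogen in place of methyl on a saturated chain carbon bound to an oxygen on a saturated carbon. For the measured compounds named here, the change is small, a single carbon trimmed from a side chain, and nothing among the measured compounds points to that carbon mattering. No step beyond the scatter is expected from compound 2 to compound 3 in this assay; the expected move is a step that the limit leaves unreadable from compound 2 to compound 3. Compound 3 is estimated at 25000 nM, with a range from 8000 nM to 80000 nM, and it may well come back as a limit again.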

Compound 3, half-maximal inhibitory concentration: 5400 nM
Beside the measured number, compound 3's estimate is 4.6-fold (0.67 log units) above it; the whole stated range lies above it.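

The side chain is not silent at this place: in this assay, trimming ethoxymethyl to methoxymethyl gives an at least 3.5-fold lower number from compound 2 to compound 3 (0.54 log units; beyond the scatter) and so shows that hydrogen in place of methyl on a saturated chain carbon bound to an oxygen on a saturated carbon is enough to turn a limit into a measured number. Until now the ether chain was known only through a limit, and nothing showed that the end of that chain counted for anything; a single methyl there now separates a compound with a number from one without. The step is only a bound and its full size stays unread, because compound 2 has no number: the limit of > 19000 nM in this assay, at which 1 of the 3 values shown sits.

From the compounds shown here alone, whether the read-out would keep moving with hydroxymethyl at this place, or with a longer chain such as propoxymethyl or with an amine on the chain, stays open. Two ether chains are too few to tell whether the number follows chain length or some other feature of the group at this place.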